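The source may report more compounds than this note shows. Statements on the series, on what has been measured and on what is new or still open speak of the compounds shown alone.

Compounds measured so far in an assay on CHO cells for binding affinity to 5-hydroxytryptamine receptor 1D (Homo sapiens); a lower number here means a stronger inhibitor, a higher number a weaker inhibitor:
compound 1 `COC[C@H](NC1CCN(CCCc2c[nH]c3ccc(-n4cnnc4)cc23)CC1)c1ccccc1` — 3 nM
compound 2 `OCCC(NC1CCN(CCCc2c[nH]c3ccc(-n4cnnc4)cc23)CC1)c1ccccc1` — 5.5 nM
compound 3 `NC(=O)OC[C@H](NC1CCN(CCCc2c[nH]c3ccc(-n4cnnc4)cc23)CC1)c1ccccc1` — 4.7 nM

Compound 2 carries the highest of the three numbers, but its gaps to the other two are within the scatter: a 1.8-fold higher number from compound 1 to compound 2 (0.26 log units; within the scatter) and a 1.2-fold lower number from compound 2 to compound 3 (0.07 log units; within the scatter). The three compounds share the same core and differ only in the group on the amine nitrogen.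

Compound 4 `CC(CO)(NC1CCN(CCCc2c[nH]c3ccc(-n4cnnc4)cc23)CC1)c1ccccc1` is not yet measured. It keeps every atom of compound 2 and rearranges them: 1-(hydroxymethyl)-1-phenylethyl in place of 3-hydroxy-1-phenylpropyl on an amine nitrogen.

Two measured steps change the same group on the same nitrogen. a 1.8-fold higher number from compound 1 to compound 2 (0.26 log units; within the scatter) and a 1.6-fold higher number from compound 1 to compound 3 (0.19 log units; within the scatter) both stay within the scatter, so neither exchange of the side group on this nitrogen has moved the number in this assay. Among the compounds with values here, compound 4 changes that group once more, and with the same atoms; no measured step puts a branched, fully substituted carbon next to this nitrogen, so the expectation rests on the pattern that the group has so far been tolerant of change.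

For compound 4 a number close to compound 2 is expected, a 1.1-fold higher number from compound 2 to compound 4 (0.04 log units; within the scatter), within the scatter. The estimate for compound 4 is 6 nM, with a range from 2.5 nM to 18 nM.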

Compound 4, half-maximal inhibitory concentration: 5.2 nM
Estimate against measurement, compound 4: 1.2-fold (0.06 log units) above, and the stated range covers the measured number.
By their numbers in this assay, from the lowest: compounds 1, 3, 4 and 2 (each within the scatter of the next).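

In this assay, the 1-(hydroxymethyl)-1-phenylethyl group on the amine nitrogen gives the first branched, fully substituted carbon at this place, yet rearranging the same atoms of 3-hydroxy-1-phenylpropyl leaves the number unmoved (a 1.1-fold lower number from compound 2 to compound 4 (0.02 log units; within the scatter)). The other two comparisons agree, with a 1.1-fold higher number from compound 3 to compound 4 (0.04 log units; within the scatter) and a 1.7-fold higher number from compound 1 to compound 4 (0.24 log units; within the scatter), so all four side groups on this nitrogen remain within the scatter of one another and none of the four goes against this tolerance. Nothing at hand gives a reason for this tolerance.

Open, going by these compounds, is whether the number holds when an amine or a carboxylic acid replaces the hydroxyl of 1-(hydroxymethyl)-1-phenylethyl, or when a longer chain carries that group. On these data alone, all four compounds keep the phenyl ring, so what a cyclohexyl group would do in its place also stays open.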